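This account rests on a few compounds, and the source may have more. Where it says the series, first, only, none or still open, it means among the compounds named here.

Compound 1 `NC(=O)CCCC/C=C(\c1ccccc1)c1cccnc1` was tested in an assay (Equus caballus) for inhibition of Thromboxane-A synthase (Homo sapiens), using microsomes (a higher number here means a weaker inhibitor, a lower number a stronger inhibitor), where compound 1 gives 400 nM. Compound 2 `C/C(=C\CCCCC(=O)O)c1cccnc1` gives 210 nM in this assay, a gap that sits within the usual scatter. Compound 3 `O=C(O)CCCCCCCCC/C=C(\c1ccccc1)c1cccnc1` gives 55 nM, clearly lower than the value of compound 1. Within the data shown here, the one measured single change from compound 1 is a 7.3-fold lower number from compound 1 to compound 3 (0.86 log units; beyond the scatter), a modest gain in potency.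

Compound 4 `C=C(C)C(CCC/C=C(\c1ccccc1)c1cccnc1)C(=O)O` differs from compound 1 by 1-carboxy-2-methylprop-2-en-1-yl in place of carbamoylmethyl on a saturated chain carbon, three bonds along the chain from a double-bonded chain carbon. Like the change to compound 3, this swaps the amide for a carboxylic acid, although the chain is not lengthened in the same way. A modest gain is therefore expected, smaller than that step: a 2.7-fold lower number from compound 1 to compound 4 (0.43 log units; beyond the scatter). In this assay compound 4 is estimated at 150 nM, with a likely range of 60 nM to 400 nM.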

Compound 4, half-maximal inhibitory concentration: 28 nM
The estimate for compound 4 lay 5.4-fold (0.73 log units) above the measured number; the whole stated range lies above it.
By their numbers in this assay, from the lowest: compounds 4 and 3 (each within the scatter of the next); then compounds 2 and 1 (each within the scatter of the next).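

Putting 1-carboxy-2-methylprop-2-en-1-yl in place of carbamoylmethyl on this saturated chain carbon gives a 14-fold lower number from compound 1 to compound 4 (1.15 log units; beyond the scatter), a large gain in potency. Compound 4 thus shows that a carboxylic acid on a branched chain, without the long chain of compound 3, can also improve on the amide of compound 1. No supporting data bear on why this gain is so large.

From the compounds shown here alone, the acid and the alkene-bearing branch enter together, so their separate contributions remain open. An unbranched carboxymethyl group or a methyl ester at this position would help separate them.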